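A Hydroxy Group on the Linker of Compound 1

The compounds below may be only part of what the source reports. "The series", "measured", "known", "first", "only" and "open" are said of these compounds alone.

Compound 1 `CC(C)c1ccccc1OCCCN1CCC(NS(=O)(=O)c2cccc(F)c2)CC1`: 52 nM
Compound 2 `CC(C)c1ccccc1OCCCN1CCC(NS(=O)(=O)c2ccc(F)cc2)CC1`: 32 nM

Both were tested in an assay on HEK293 cells for displacement of a labelled ligand from 5-hydroxytryptamine receptor 7 (Homo sapiens), read by scintillation counting, with a stated time of 1 h; a lower number here means a stronger inhibitor, a higher number a weaker inhibitor. Among the compounds with values here, compound 1 sits within the scatter of compound 2, the only other number, and the single measured step, a 1.6-fold lower number from compound 1 to compound 2 (0.21 log units; within the scatter), concerns the sulfonyl ring alone. Compound 3 `CC(C)c1ccccc1OCC(O)CN1CCC(NS(=O)(=O)c2cccc(F)c2)CC1` carries hydroxy in place of hydrogen on a saturated chain carbon bound to two saturated chain carbons. Within the data shown here, no measured step touches this chain, so nothing on record bears on the change, and no direction can be read from it; the expectation is a step no larger than the scatter. Compound 3 is therefore estimated at 70 nM, within 25 nM to 200 nM, an expected 1.3-fold higher number from compound 1 to compound 3 (0.13 log units; within the scatter).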

Compound 3, inhibition constant: 213 nM
Compound 3: middle estimate off by 3.0-fold (0.48 log units), on the low side; the measured number lies above the stated range.
By their numbers in this assay, from the lowest: compounds 2 and 1 (each within the scatter of the next); then compound 3.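

Within the data shown here, compound 3 gives the first measured step at this chain, and in this assay hydroxy in place of hydrogen brings a 4.1-fold higher number from compound 1 to compound 3 (0.61 log units; beyond the scatter) and so a weaker inhibitor. Unlike the earlier step on the sulfonyl ring, this one lies beyond the scatter, so this chain carbon does not tolerate every change without loss. Nothing on record explains the loss.

From the compounds shown here alone, whether a methoxy group, a fluorine or an amine on this carbon would cost as much stays open. So does the effect of hydroxy when 4-fluorophenyl sits on the sulfonyl sulfur.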